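From methoxy to amino on the shared core

A few compounds are considered here, and "the series" means these few. Any claim that something is new, unique, unknown or untested is made for them only; others in the source may bear on it.

Of the compounds shown here, three built on the same shared core have been measured in a functional assay on MCF7 cells (Homo sapiens) for antiproliferative activity; a lower number here means a stronger inhibitor, a higher number a weaker inhibitor. Compound 1 `CN(C)C1=CC(=O)c2[nH]c(-c3ccccn3)nc2C1=O` gives > 90 uM, which is a limit of the assay rather than a number. Compound 2 `O=C1C(Br)=CC(=O)c2[nH]c(-c3ccccn3)nc21` likewise gives > 90 uM, again a limit. For the measured compounds named here, compound 3 `COC1=CC(=O)c2[nH]c(-c3ccccn3)nc2C1=O` gives 26.4 uM in this assay, the only actual number among the three. The other two values sit at the limit of > 90 uM in this assay, at which 2 of the 3 values shown sit.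

Compound 4 `NC1=CC(=O)c2[nH]c(-c3ccccn3)nc2C1=O` differs from compound 3 in one place: amino in place of methoxy on a double-bonded ring carbon. Going by the values given here, two measured steps concern that same place. Replacing dimethylamino by methoxy gave an at least 3.4-fold lower number from compound 1 to compound 3 (0.53 log units; beyond the scatter), and replacing bromo by methoxy gave an at least 3.4-fold lower number from compound 2 to compound 3 (0.53 log units; beyond the scatter). The remaining step is a step that the two limits leave unreadable from compound 1 to compound 2. Among the compounds with values here, neither measured step involves amino itself, so the expectation for compound 4 rests on methoxy having given the lowest number so far, while dimethylamino, the group that shares a nitrogen with amino, gave only a limit. A modest move to a higher number is expected for compound 4, a 1.7-fold higher number from compound 3 to compound 4 (0.23 log units; within the scatter). Compound 4 is therefore estimated at 45 uM, within a range from 15 uM to 130 uM.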

Compound 4, concentration for 50% inhibition: > 90 uM
Compound 4: only a limit was reported (the forecaster's own chance of this, stated with the estimate: 30%); at least 2.0-fold (0.30 log units) between middle value and limit.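

This result shows that the step in this assay from methoxy to amino on the double-bonded ring carbon is a real loss: an at least 3.4-fold higher number from compound 3 to compound 4 (0.53 log units; beyond the scatter). Before compound 4, only dimethylamino stood for a nitrogen at this place, so its limit might have been tied to that one group, but amino now gives a limit too. Among the compounds shown, a measurable value appears with methoxy alone, and compound 2 shows that this is not simply a split between oxygen and nitrogen, as its bromo also ends at a limit: the limit of > 90 uM in this assay, at which 3 of the 4 values shown sit.

On these data alone, the steps that link compound 4 with compound 1 and compound 2 cannot be read, as both ends of each are limits, and so the order of these three stays unknown. As far as these compounds go, it also remains open how narrowly the value of compound 3 depends on methoxy itself, a question that ethoxy, with a longer chain on the same oxygen, or hydroxy, with no carbon on that oxygen, could answer at the same place.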